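Phenyl substitution on the carbonyl carbon: compounds 1 to 4

This account rests on a few compounds, and the source may have more. Where it says the series, first, only, none or still open, it means among the compounds named here.

Measured compounds:
- compound 1, `N#Cc1cccc(C(=O)NCN2CCC(c3cccc[n+]3[O-])CC2)c1`: 69%
- compound 2, `O=C(NCN1CCC(c2cccc[n+]2[O-])CC1)c1cc(Cl)cc(Cl)c1`: 64%
- compound 3, `O=C(NCN1CCC(c2cccc[n+]2[O-])CC1)c1ccccc1`: 63%

All three share one core and differ only in the group on the carbonyl carbon; each was run in a functional assay on HEK293 cells for agonist activity at D(4) dopamine receptor (Homo sapiens), read by FLIPR; on this read-out lower numbers stand for smaller maximal responses and higher numbers for larger maximal responses. On the numbers shown compound 3 sits at the low end of the three, yet a number 6 percentage points lower from compound 1 to compound 3 (within the scatter) and a number 1 percentage points lower from compound 2 to compound 3 (within the scatter) are both within the scatter, so the three cannot be told apart on this read-out.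

Compound 4, `O=C(NCN1CCC(c2cccc[n+]2[O-])CC1)c1ccc(F)c(Cl)c1`, is not yet measured. It differs from compound 3 by 3-chloro-4-fluorophenyl in place of phenyl on a carbonyl carbon. Among the compounds with values here, the steps that bear on this are the earlier changes at the same carbonyl carbon: a number 5 percentage points lower from compound 1 to compound 2 (within the scatter) and a number 1 percentage points lower from compound 2 to compound 3 (within the scatter), both within the scatter. Nothing in the three measured compounds points to a step beyond the scatter in this assay from such a change, so none is expected: the estimated step is a number 2 percentage points higher from compound 3 to compound 4 (within the scatter). Compound 4 is therefore expected to give about 65% in this assay, with a range from 55% to 76%.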

Compound 4, largest response reached (reported as efficacy), in percent of the reference or control that the assay uses: 67%
For compound 4 the middle estimate is 2 percentage points below the measured one, within the range that was stated.
By their numbers in this assay, from the lowest: compounds 3, 2, 4 and 1 (each within the scatter of the next).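

Across this assay, 3-chloro-4-fluorophenyl on the carbonyl carbon stays level with the other three groups, with a number 4 percentage points higher from compound 3 to compound 4 (within the scatter), a number 3 percentage points higher from compound 2 to compound 4 (within the scatter) and a number 2 percentage points lower from compound 1 to compound 4 (within the scatter). A group carrying both fluorine and chlorine therefore extends the set of phenyl groups at this position without producing a step beyond the scatter, so phenyl, 3-cyanophenyl, 3,5-dichlorophenyl and 3-chloro-4-fluorophenyl remain indistinguishable on maximal response. Nothing available here offers an explanation for this flat result.

Still open, on these data alone, is whether any group at this carbonyl carbon can move the maximal response beyond the scatter, for instance a phenyl ring bearing a carboxylic acid or an amine. A cyclohexyl or a longer alkyl chain in place of the phenyl ring would show whether an aromatic ring is needed here at all.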